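From 2-methylphenyl to 4-methylphenyl on a carbonyl carbon

This account rests on a few compounds, and the source may have more. Where it says the series, first, only, none or still open, it means among the compounds named here.

In a functional assay on MDA-MB-231 cells (Homo sapiens) for antiproliferative activity, read by MTT assay, with a stated time of 24 h (on this read-out lower numbers stand for stronger inhibition and higher numbers for weaker inhibition), compound 1 `O=C(NNc1ccc(F)cc1)c1ccc(NS(=O)(=O)c2cnc(O)nc2O)cc1` reaches only a limit, > 20000 nM. Compound 2 `CCCCOc1ccc(C(=O)NNC(=O)c2ccc(NS(=O)(=O)c3cnc(O)nc3O)cc2)cc1` gives 11900 nM and compound 3 `Cc1ccccc1C(=O)NNC(=O)c1ccc(NS(=O)(=O)c2cnc(O)nc2O)cc1` gives 7040 nM. These two numbers stand together, with a 1.7-fold lower number from compound 2 to compound 3 (0.23 log units; within the scatter). Compound 3 is set apart from the limit of the other compound by an at least 2.8-fold lower number from compound 1 to compound 3 (0.45 log units; beyond the scatter).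

Compound 4 `Cc1ccc(C(=O)NNC(=O)c2ccc(NS(=O)(=O)c3cnc(O)nc3O)cc2)cc1` carries 4-methylphenyl in place of 2-methylphenyl on a carbonyl carbon. For the measured compounds named here, the closest precedent is the change at that same place between compound 2 and compound 3, where a 1.7-fold lower number from compound 2 to compound 3 (0.23 log units; within the scatter). No change beyond the scatter is therefore expected in this assay. The expected step is a 1.1-fold higher number from compound 3 to compound 4 (0.06 log units; within the scatter). Compound 4 is estimated at 8000 nM, within an expected range of 3500 nM to 18000 nM.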

Compound 4, half-maximal inhibitory concentration: > 20000 nM
Compound 4 was reported as a limit (the forecaster's own chance of this, stated with the estimate: 12%); middle value at least 2.5-fold (0.39 log units) from the limit.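

For the compounds shown here, with the same atoms joined differently, 4-methylphenyl in place of 2-methylphenyl on a carbonyl carbon gives an at least 2.8-fold higher number from compound 3 to compound 4 (0.45 log units; beyond the scatter), so in this assay the place of the methyl on this ring matters, which the earlier compounds did not show. The change of butoxy to methyl reads an at least 1.6-fold higher number from compound 2 to compound 4 (0.22 log units; that floor lies within the scatter), and the remaining step, between two limits, cannot be read. Compound 4 is reported only as a limit, so its steps have a floor and no size: the limit of > 20000 nM in this assay, at which 2 of the 4 values shown sit.

As far as these compounds go, whether an amine or a chlorine in place of the methyl would hold the number of compound 3 stays open.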